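Adding a Methyl to Compound 2's Hydroxy Group

This account rests on a few compounds, and the source may have more. Where it says the series, first, only, none or still open, it means among the compounds named here.

In a functional assay on MDA-MB-231 cells (Homo sapiens) for antiproliferative activity, read by MTT assay, with a stated time of 48 h (a higher number here means a weaker inhibitor of growth, a lower number a stronger inhibitor of growth), compound 1 `COc1ccc(/C=C2\Cc3c(cc(OC)c(OC)c3OC)C2=O)cc1O` gives 570 nM while compound 2 `COc1cc2c(cc1O)C(=O)/C(=C/c1ccc(OC)c(OC)c1OC)C2` gives 2410 nM as the higher of the two numbers. This gap lies beyond the scatter, so compound 2 is the weaker inhibitor of growth.

Compound 3 `COc1cc2c(cc1OC)C(=O)/C(=C/c1ccc(OC)c(OC)c1OC)C2` carries one change methyl in place of hydrogen on an oxygen on an aromatic ring from compound 2: methyl in place of hydrogen on an oxygen on an aromatic ring, or hydroxy to methoxy. Among the measured compounds shown here, no measured pair shows this change alone, so the evidence is thin. The expected 1.2-fold lower number from compound 2 to compound 3 (0.08 log units; within the scatter) stays within the scatter, with no clear direction. In this assay compound 3 is expected at 2000 nM with an estimated range from 500 nM to 8000 nM for now.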

Compound 3, concentration for 50% growth inhibition: > 10000 nM
Compound 3: only a limit was reported; the forecaster's own chance of this, stated with the estimate: 10%; middle value at least 5.0-fold (0.69 log units) away from the limit.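

In this assay, among the compounds shown here, the change from hydroxy to methoxy at this position gives an at least 4.1-fold higher number from compound 2 to compound 3 (0.61 log units; beyond the scatter) and so shows that adding this one methyl on the oxygen weakens growth inhibition, which the earlier compounds, differing in more than one place, could not show. The reading for compound 3 is a limit, not a number: the limit of > 10000 nM in this assay, at which 1 of the 3 values shown sits.

From the compounds shown here alone, whether an ethyl group on this oxygen, or an amine in place of the hydroxy, would keep growth inhibition remains open. So does whether methyl on the hydroxy of compound 1 acts the same way.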